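This account rests on a few compounds, and the source may have more. Where it says the series, first, only, none or still open, it means among the compounds named here.

Of the compounds shown here, three built on the same core have been measured. In a functional assay on HT-29 cells (Homo sapiens) for cytotoxicity, read by MTT assay, with a stated time of 72 h (a lower number here means a stronger inhibitor, a higher number a weaker inhibitor), compound 1 `COc1ccc(C(=O)c2cc(OC)c(OC)c(OC)c2)cc1NC(=O)/C=C/c1cc(OC)c(OC)c(OC)c1` gives 3100 nM. Compound 2 `COc1ccc(C(=O)c2cc(OC)c(OC)c(OC)c2)cc1NC(=O)/C=C/c1ccc(OC)c(OC)c1` gives 2500 nM in this assay. Compound 3 `COc1cccc(/C=C/C(=O)Nc2cc(C(=O)c3cc(OC)c(OC)c(OC)c3)ccc2OC)c1` gives 1900 nM in this assay, the lowest of the three numbers, though every gap among them lies within the scatter, so no order among the three can be claimed.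

The measured steps all concern methoxy groups on the phenyl ring at the far end of the double-bonded chain: a 1.2-fold lower number from compound 1 to compound 2 (0.09 log units; within the scatter), a 1.6-fold lower number from compound 1 to compound 3 (0.21 log units; within the scatter) and a 1.3-fold lower number from compound 2 to compound 3 (0.12 log units; within the scatter). Each of these trimmings of methoxy groups left the number essentially where it was.

Compound 4 `COc1ccc(C(=O)c2cc(OC)c(OC)c(OC)c2)cc1NC(=O)/C=C/c1ccc(C(F)(F)F)cc1` goes one step further in the same place: 4-(trifluoromethyl)phenyl in place of 3-methoxyphenyl on a double-bonded chain carbon bound to a double-bonded chain carbon. The earlier steps shown here bear on it only in part, since they removed methoxy groups but never put a trifluoromethyl group in; nothing measured here shows what that group does. The changes to this ring so far stayed within the scatter. Little movement is therefore expected, in no firm direction. Compound 4 is estimated to give 2200 nM in this assay, with a range from 700 nM to 7000 nM. This amounts to an expected step of a 1.2-fold higher number from compound 3 to compound 4 (0.06 log units; within the scatter).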

Compound 4, half-maximal inhibitory concentration: 1600 nM
The estimate for compound 4 lay 1.4-fold (0.14 log units) above the measured number; low and high end bracket the measured number.
By their numbers in this assay, from the lowest: compounds 4, 3, 2 and 1 (each within the scatter of the next).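

For the compounds shown here, this is the first change at this position that puts something other than a methoxy group on the phenyl ring. The 4-(trifluoromethyl)phenyl group carries no methoxy group at all, yet in this assay every step to compound 4 stays within the scatter: (a 1.2-fold lower number from compound 3 to compound 4 (0.07 log units; within the scatter)), (a 1.6-fold lower number from compound 2 to compound 4 (0.19 log units; within the scatter)) and (a 1.9-fold lower number from compound 1 to compound 4 (0.29 log units; within the scatter)). Among these four compounds, then, the methoxy groups on this ring are not required to keep the number in this range, and a trifluoromethyl group can stand in their absence without a readable shift, although nothing available explains this result.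

As far as these compounds go, it remains open whether any group on this ring can move the number beyond the scatter, for instance an amine, a carboxylic acid or a longer chain ending in a hydroxyl group. The shared core is the same in all four compounds, so these results also say nothing about how a change to the amide, the carbonyl or the 3,4,5-trimethoxyphenyl ring on the other side would act.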